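Hydroxymethyl to Amino: an Estimate for Compound 4

This account rests on a few compounds, and the source may have more. Where it says the series, first, only, none or still open, it means among the compounds named here.

Compound 1 `CCc1ccc(-c2ccc(N(C[C@@H](N)[C@@H](C)CC)C(=O)[C@@H]3C[C@H]3c3ccccc3)cc2)cc1` gives 44 nM in a functional assay for agonist activity at G protein-coupled receptor 88 (Homo sapiens), read by HTRF and cAMP accumulation; a lower number here means that less compound is needed, a higher number that more compound is needed for the effect.
Compound 2 `CCOc1ccc(-c2ccc(N(C[C@@H](N)[C@@H](C)CC)C(=O)[C@@H]3C[C@H]3c3ccccc3)cc2)cc1` gives 90 nM in this assay.
Compound 3 `CC[C@H](C)[C@H](N)CN(C(=O)[C@@H]1C[C@H]1c1ccccc1)c1ccc(-c2ccc(CO)cc2)cc1` gives 1100 nM in this assay.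

Compound 3 stands at the highest number of the three measured, set apart by the steps of a 25-fold higher number from compound 1 to compound 3 (1.40 log units; beyond the scatter) and a 12-fold higher number from compound 2 to compound 3 (1.09 log units; beyond the scatter). Compound 4 `CC[C@H](C)[C@H](N)CN(C(=O)[C@@H]1C[C@H]1c1ccccc1)c1ccc(-c2ccc(N)cc2)cc1` differs from it by amino in place of hydroxymethyl on an aromatic carbon. All three measured steps concern the same aromatic carbon: a 2.0-fold higher number from compound 1 to compound 2 (0.31 log units; beyond the scatter) was modest, while the two steps that bring in hydroxymethyl, a group with a hydrogen-bond donor and acceptor, were large. The amino group of compound 4 again carries one donor and one acceptor but is smaller by one heavy atom, so the expected step from compound 3 is a 1.4-fold higher number from compound 3 to compound 4 (0.13 log units; within the scatter), close to the scatter. Compound 4 is therefore estimated at 1500 nM in this assay, with a range of 400 nM to 6000 nM.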

Compound 4, half-maximal effective concentration: 320 nM
Beside the measured number, compound 4's estimate is 4.7-fold (0.67 log units) above it, and the stated range ends above it.
By their numbers in this assay, from the lowest: compound 1; then compound 2; then compound 4; then compound 3.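

At this aromatic carbon in this assay, hydroxymethyl and amino share the same donor and acceptor counts, yet the change still gave a 3.4-fold lower number from compound 3 to compound 4 (0.54 log units; beyond the scatter), so those counts alone do not set the number. Amino nevertheless remains behind both ethoxy and ethyl, with a 3.6-fold higher number from compound 2 to compound 4 (0.55 log units; beyond the scatter) and a 7.3-fold higher number from compound 1 to compound 4 (0.86 log units; beyond the scatter). No available evidence accounts for these differences. Going by these compounds, whether dimethylamino, a carboxylic acid or a longer alkyl chain at this carbon would stand nearer ethyl or nearer hydroxymethyl remains open.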